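Phenyl for methyl in a cyanobenzyl triazole series

The source may hold more compounds than are shown below. What is called first, only, known or untested is meant among the compounds shown, and "the series" means these compounds.

Compounds measured so far:
compound 1 `N#Cc1ccc(C(c2ccc(C#N)cc2)n2cc(COc3ccc(-c4ccccc4)cc3)nn2)cc1` – 13400 nM
compound 2 `N#Cc1ccc(Cn2cc(COc3ccc(C#N)cc3)nn2)cc1` – 9160 nM
compound 3 `Cc1ccc(OCc2cn(Cc3ccc(C#N)cc3)nn2)cc1` – 4170 nM

In an assay on isolated protein for inhibition of Aromatase (Homo sapiens), read by fluorescence and colorimetric assay, with a stated time of 30 min (on this read-out lower numbers stand for stronger inhibition and higher numbers for weaker inhibition), compound 3 gives the lowest of the three numbers; compound 2 sits nearer to it and compound 1 furthest away. For the measured compounds named here, the only single-point step among the measured compounds is a 2.2-fold lower number from compound 2 to compound 3 (0.34 log units; beyond the scatter), a modest change. Compound 4 `N#Cc1ccc(Cn2cc(COc3ccc(-c4ccccc4)cc3)nn2)cc1` arises from compound 3 by phenyl in place of methyl on an aromatic carbon, the phenyl entering on an aromatic carbon of a six-membered aromatic ring of carbon only, para to a large group. Going by the values given here, no measured step concerns the same exchange: compound 1 also carries the phenyl, but it differs from compound 3 at a second place as well, so its number can only be set beside that of compound 3, not read as a step. On that basis compound 4 is expected to give 6000 nM, in the range 2500 nM to 15000 nM, which means an estimated step of a 1.4-fold higher number from compound 3 to compound 4 (0.16 log units; within the scatter), likely within or only just beyond the scatter.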

Compound 4, half-maximal inhibitory concentration: 11600 nM
The estimate for compound 4 lay 1.9-fold (0.29 log units) below the measured number; low and high end bracket the measured number.
By their numbers in this assay, from the lowest: compound 3; then compounds 2, 4 and 1 (each within the scatter of the next).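

In this assay, the position on an aromatic carbon of a six-membered aromatic ring of carbon only, para to a large group, now has a third group, and phenyl in place of methyl gives a 2.8-fold higher number from compound 3 to compound 4 (0.44 log units; beyond the scatter) and so does not keep the lower number seen with methyl. Phenyl in place of cyano at that position gives a 1.3-fold higher number from compound 2 to compound 4 (0.10 log units; within the scatter) and so does not separate these two groups, which leaves methyl alone apart from them among the three groups compared here. With phenyl at that position, hydrogen in place of 4-cyanophenyl on the saturated chain carbon gives a 1.2-fold lower number from compound 1 to compound 4 (0.06 log units; within the scatter) and so does not separate these two compounds either.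

From the compounds shown here alone, how an amine, a carboxylic acid or a methoxy group would read at this position stays open. No available evidence bears on why methyl and phenyl differ here.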